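Dimethylamino to methyl in the naphthalen-2-yl series

The source may report more compounds than this note shows. Statements on the series, on what has been measured and on what is new or still open speak of the compounds shown alone.

Measured in a functional assay on HL-60 cells (Homo sapiens) for antiproliferative activity, read by MTT assay, with a stated time of 72 h; on this read-out higher numbers stand for weaker inhibition and lower numbers for stronger inhibition:
- Compound 1 `CNc1nc(-c2cc(OC)c(OC)c(OC)c2)c(-c2ccc3ccccc3c2)s1`: 143 nM
- Compound 2 `COc1cc(-c2nc(N(C)C)sc2-c2ccc3ccccc3c2)cc(OC)c1OC`: 2570 nM

Compound 2 stands higher of the two, at 2570 nM. Compound 3 `COc1cc(-c2nc(C)sc2-c2ccc3ccccc3c2)cc(OC)c1OC` carries methyl in place of dimethylamino on an aromatic carbon. Among the compounds with values here, the only measured step, an 18-fold higher number from compound 1 to compound 2 (1.25 log units; beyond the scatter), is large and comes from methyl in place of hydrogen on a nitrogen on an aromatic ring. Within the data shown here, no measured step shows the exact change to compound 3, so the expectation is loose: a moderate to large move to a lower number in this assay. The estimated step is a 5.1-fold lower number from compound 2 to compound 3 (0.71 log units; beyond the scatter). For compound 3, the expected value is 500 nM, with an estimated range of 110 nM to 2300 nM.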

Compound 3, half-maximal inhibitory concentration: 205 nM
Estimate against measurement, compound 3: 2.4-fold (0.39 log units) above; the measured number falls inside the stated range.
By their numbers in this assay, from the lowest: compounds 1 and 3 (each within the scatter of the next); then compound 2.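

In this assay, methyl in place of dimethylamino on this aromatic carbon gives a 13-fold lower number from compound 2 to compound 3 (1.10 log units; beyond the scatter), so the tertiary amine of compound 2 is not needed for activity in this series. Methyl in place of methylamino gives a 1.4-fold higher number from compound 1 to compound 3 (0.16 log units; within the scatter), so among the three compounds a nitrogen at this position is not required, and only dimethylamino stands apart. Nothing available here bears on the reason for this difference. Open, as far as these compounds go, is how an unsubstituted amino group or an ethyl chain on this carbon would read.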